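A few compounds are considered here, and "the series" means these few. Any claim that something is new, unique, unknown or untested is made for them only; others in the source may bear on it.

Compound 1 `Cc1nc2c(OCc3ccccc3)nccn2c1N` gives 65% in a functional assay on the whole organism with Canis familiaris (Canis lupus familiaris) as the target, at a dose of 2 mg/kg by the intravenous route; on this read-out higher numbers stand for a stronger effect at the one dose given and lower numbers for a weaker effect.
Compound 2 `Cc1nc2c(OCc3ccccc3)cccn2c1NC=O` gives 3% in this assay.

Compound 2 stands lowest of the two measured numbers; the value of compound 1 lies far above it, beyond the scatter. Compound 3 `Cc1nc2c(OCc3ccccc3)cccn2c1N(C)C` is the next step from compound 2, with dimethylamino in place of formylamino on an aromatic carbon. Among the compounds with values here, no measured pair shows this change on its own, so its size is uncertain. Compound 3 is expected to rise by a number 27 percentage points higher from compound 2 to compound 3 (beyond the scatter), partly because compound 1, which also carries no formylamino, gave 65%. The estimate for compound 3 in this assay is 30%, between 5% and 65%.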

Compound 3, a percentage reported as inhibition, in the whole organism at one dose (the size of the read-out at that dose, not a potency): 85%
The estimate for compound 3 lay 55 percentage points below the measured number; the measured number lies above the stated range.
By their numbers in this assay, from the lowest: compound 2; then compound 1; then compound 3.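

At this aromatic carbon, dimethylamino in place of formylamino gives a number 82 percentage points higher from compound 2 to compound 3 (beyond the scatter) in this assay. This is the first change in one place among these compounds, and it shows that the read-out at the one dose given depends strongly on the group at this position. No measurement shown accounts for the size of this step.

From the compounds shown here alone, whether the gain comes with the arrival of dimethylamino or with the departure of formylamino stays open. A plain amine, methylamino or diethylamino at this carbon on the core of compound 3 would help to separate the two.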